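The source may report more compounds than this note shows. Statements on the series, on what has been measured and on what is new or still open speak of the compounds shown alone.

Compound 1 `O=S(=O)(Nc1ccc(-c2nc3ccccc3o2)cc1)c1cccs1`: in an assay on cells for inhibition of HSP60/HSP10 (Homo sapiens), with a stated time of 60 min (on this read-out lower numbers stand for stronger inhibition and higher numbers for weaker inhibition), compound 1 gives 63000 nM.
Compound 2 `O=S(=O)(Nc1ccc(-c2nc3ccccc3o2)cc1)c1ccccc1O`: in this assay compound 2 reaches only a limit, > 100000 nM.
Compound 3 `O=S(=O)(Nc1ccc(-c2nc3cc(NS(=O)(=O)c4ccccc4F)ccc3o2)cc1)c1ccccc1F`: in this assay compound 3 gives 57000 nM.

Compound 3 holds the lowest of the two numbers, though its gap to compound 1 lies within the scatter, and the third value is a limit (the limit of > 100000 nM in this assay, at which 1 of the 3 values shown sits). Compound 4 `O=S(=O)(Nc1ccc(-c2nc3ccccc3o2)cc1)c1ccccc1F` differs from compound 3 by hydrogen in place of ((2-fluorophenyl)sulfonyl)amino on an aromatic carbon. Going by the values given here, the only measured step, an at least 1.5-fold higher number from compound 1 to compound 2 (0.20 log units; that floor lies within the scatter), concerns an exchange on the sulfonyl sulfur and does not bear on this removal; no measured pair shows it. Compound 1 carries a single sulfonamide and gives 63000 nM, close to compound 3. No step beyond the scatter is therefore expected, a 1.2-fold higher number from compound 3 to compound 4 (0.09 log units; within the scatter). Compound 4 is estimated at 70000 nM, in the range 25000 nM to 200000 nM.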

Compound 4, half-maximal inhibitory concentration: > 100000 nM
Compound 4 was reported as a limit; the forecaster's own chance of this, stated with the estimate: 30%; at least 1.4-fold (0.15 log units) between middle value and limit.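

In this assay, the first measured change at this aromatic carbon, loss of the ((2-fluorophenyl)sulfonyl)amino group, gives an at least 1.7-fold higher number from compound 3 to compound 4 (0.24 log units; that floor lies within the scatter), and the exchange on the sulfonyl sulfur gives an at least 1.5-fold higher number from compound 1 to compound 4 (0.20 log units; that floor lies within the scatter); neither floor passes the scatter, so neither change is shown to matter. The step linking the two limit compounds, compound 2 and compound 4, cannot be read. Compound 4 now shares a limit with compound 2: the limit of > 100000 nM in this assay, at which 2 of the 4 values shown sit.

Going by these compounds, whether an amine or a carboxylic acid on this aromatic carbon would give a readable number stays open. On these data alone, how far compound 2 and compound 4 lie past their limit also stays open.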